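Lengthening the carbamate ester from compound 3 to compound 4

A few compounds are considered here, and "the series" means these few. Any claim that something is new, unique, unknown or untested is made for them only; others in the source may bear on it.

In an assay on COS-7 cells for inhibition of patatin-like phospholipase domain-containing protein 2 (Mus musculus), tested at 200 uM (on this read-out higher numbers stand for more inhibition at the one concentration tested (going by the name of the read-out) and lower numbers for less inhibition), compound 1 `CN(C)c1ccc(-c2cccc(N)c2)cc1` gives 70%. Putting a group in place of the hydrogen on a nitrogen on an aromatic ring raises the number: compound 2 `CN(C)C(=O)Nc1cccc(-c2ccc(N(C)C)cc2)c1` gives 98%, and compound 3 `COC(=O)Nc1cccc(-c2ccc(N(C)C)cc2)c1` gives 95%. The steps of a number 28 percentage points higher from compound 1 to compound 2 (beyond the scatter) and a number 25 percentage points higher from compound 1 to compound 3 (beyond the scatter) both lie beyond the scatter. Compound 3 thus stands second highest of the three numbers, close to compound 2, with the step of a number 3 percentage points lower from compound 2 to compound 3 (within the scatter) lying within the scatter, and well above compound 1.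

Compound 4 `CCOC(=O)Nc1cccc(-c2ccc(N(C)C)cc2)c1` differs from compound 3 in one place: methyl in place of hydrogen on a saturated chain carbon bound to an oxygen next to a carbonyl group. Within the data shown here, the one measured step that bears on it is the exchange on the carbonyl carbon, a number 3 percentage points lower from compound 2 to compound 3 (within the scatter), which stayed within the scatter. The larger steps concerned the nitrogen on the aromatic ring, not the group on the carbonyl carbon. A small change on the carbonyl side is therefore expected to change little, with the expected step of a number 1 percentage points lower from compound 3 to compound 4 (within the scatter) within the scatter. Compound 4 is expected to give 94%, in a range from 84% to 99%.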

Compound 4, a percentage reported as inhibition, at one concentration (the size of the read-out at that concentration, not a potency): 93%
Beside the measured number, compound 4's estimate is 1 percentage points above it; the range from low to high includes it.
By their numbers in this assay, from the lowest: compound 1; then compounds 4, 3 and 2 (each within the scatter of the next).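

The added methyl on a saturated chain carbon bound to an oxygen next to a carbonyl group leaves no readable mark in this assay: the change from methoxycarbonyl to ethoxycarbonyl gives a number 2 percentage points lower from compound 3 to compound 4 (within the scatter) and so does not separate the two esters. Ethoxy on a carbonyl carbon likewise stands level with dimethylamino in a number 5 percentage points lower from compound 2 to compound 4 (within the scatter), and a number 23 percentage points higher from compound 1 to compound 4 (beyond the scatter) shows that the rise over compound 1 survives this longer ester. Nothing available explains why these numbers fall as they do.

As far as these compounds go, whether a longer chain such as butoxy, or a ring such as phenoxy, in place of ethoxy would shift the number remains open. So does whether compound 3 and compound 4 would differ at lower concentrations.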